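Working notes: bromo to methyl at compound 3

The compounds below may be only part of what the source reports. "The series", "measured", "known", "first", "only" and "open" are said of these compounds alone.

The series shares the core of compound 1 `O=C(Nc1cccc(C(F)(F)F)c1)N[C@H]1CC[C@H](O)CC1`, for which the reading in a functional assay on CRL2813 cells (Homo sapiens) for cytotoxicity, read by sulforhodamine B assay, with a stated time of 5 days (on this read-out higher numbers stand for weaker inhibition and lower numbers for stronger inhibition), is a limit, > 20000 nM, as recorded at the limit of > 20000 nM in this assay, at which 1 of the 3 values shown sits. Going by the values given here, compound 2 `O=C(Nc1cccc(C(F)(F)F)c1)N[C@H]1CC[C@H](Oc2ccc(C(F)(F)F)cc2)CC1` gives 460 nM in this assay, and the step of an at least 43-fold lower number from compound 1 to compound 2 (1.63 log units; beyond the scatter) is the only measured step in the set. Compound 3 `O=C(Nc1ccccc1Br)N[C@H]1CC[C@H](Oc2ccc(F)cc2)CC1` gives 7700 nM in this assay, the highest of the two numbers shown, with compound 2 as its nearest neighbour at a markedly lower number.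

Compound 4 `Cc1ccccc1NC(=O)N[C@H]1CC[C@H](Oc2ccc(F)cc2)CC1` differs from compound 3 by methyl in place of bromo on an aromatic carbon. Among the compounds with values here, the one measured step, an at least 43-fold lower number from compound 1 to compound 2 (1.63 log units; beyond the scatter), changes the oxygen on the saturated carbon and leaves the aromatic ring untouched, so it does not bear on the present change; no measured pair sets bromo against methyl. With no guide, a step within the scatter is the expectation, and a 1.1-fold lower number from compound 3 to compound 4 (0.04 log units; within the scatter) is what is expected. Compound 4 is therefore estimated at 7000 nM in this assay, with a range from 2500 nM to 20000 nM.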

Compound 4, half-maximal inhibitory concentration: > 20000 nM
Compound 4: a limit, no number; the forecaster's own chance of this, stated with the estimate: 20%; middle value at least 2.8-fold (0.45 log units) away from the limit.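

In this assay, going by these compounds alone, the change from 2-bromophenyl to 2-methylphenyl is the first measured change on this aromatic ring, and it is not neutral: an at least 2.5-fold higher number from compound 3 to compound 4 (0.41 log units; beyond the scatter). The two groups match in their heavy-atom and hydrogen-bond counts, yet the reading still moves beyond the scatter, so the bromo group cannot be treated as interchangeable with methyl in this series. Compound 4 gives a limit of the assay, not a number, so the step sets only a minimum size: the limit of > 20000 nM in this assay, at which 2 of the 4 values shown sit.

As far as these compounds go, whether a chloro or a methoxy group at this position would read nearer compound 3 or compound 4 remains open. Compound 2 and compound 3 differ in more than one place, and no pair shown separates the contribution of the aromatic ring from that of the ether substituent.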